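Thioether side chain: diamine to aminocyclohexyl on the shared core

The compounds below may be only part of what the source reports. "The series", "measured", "known", "first", "only" and "open" are said of these compounds alone.

Measured compounds in a functional assay on HT cells (Homo sapiens) for antiproliferative activity, read by fluorescence, with a stated time of 72 h; on this read-out higher numbers stand for weaker inhibition of growth and lower numbers for stronger inhibition of growth:
- compound 1 `CC(C)c1n[nH]c2c(NCc3ccc(-c4ccccn4)cc3)nc(SCC(O)CO)nc12`: 21 nM
- compound 2 `CC(C)c1n[nH]c2c(NCc3ccc(-c4ccccn4)cc3)nc(SC[C@H](O)CN)nc12`: 63 nM
- compound 3 `CC(C)c1n[nH]c2c(NCc3ccc(-c4ccccn4)cc3)nc(SCC(N)CN)nc12`: 480 nM

Compound 3 gives the highest number of the three, so its growth inhibition is the weakest in this assay; its nearest neighbour is compound 2 and its furthest compound 1. Each swap of a hydroxyl for an amine on the saturated chain carbon bound to the sulfur has pushed the number up: a 3.0-fold higher number from compound 1 to compound 2 (0.48 log units; beyond the scatter) and a 7.6-fold higher number from compound 2 to compound 3 (0.88 log units; beyond the scatter), and across both changes a 23-fold higher number from compound 1 to compound 3 (1.36 log units; beyond the scatter).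

Compound 4 `CC(C)c1n[nH]c2c(NCc3ccc(-c4ccccn4)cc3)nc(SC3CCCCC3N)nc12` is not yet measured. Its change from compound 3 is 2-aminocyclohexyl in place of 2,3-diaminopropyl on a sulfur. This removes one of the two amines and puts the remaining amine on a ring carbon rather than an open chain. The measured steps bear on it only in part: they show that each amine added in place of a hydroxyl cost potency, so removing one amine might reverse some of that loss. Among the measured compounds shown here, no measured pair shows a ring of carbon only in this place, so the ring's own contribution is unknown.

On this basis a modest step downwards is expected, roughly a 2.4-fold lower number from compound 3 to compound 4 (0.38 log units; beyond the scatter), and compound 4 is estimated at 200 nM with a range from 60 nM to 800 nM.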

Compound 4, concentration for 50% growth inhibition: 139 nM
Beside the measured number, compound 4's estimate is 1.4-fold (0.16 log units) above it; the range from low to high includes it.
By their numbers in this assay, from the lowest: compound 1; then compound 2; then compound 4; then compound 3.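

Working notes on the group on the sulfur, in this assay: the open chain is not required here, since 2-aminocyclohexyl in place of 2,3-diaminopropyl recovers part of the loss seen with the diamine (a 3.5-fold lower number from compound 3 to compound 4 (0.54 log units; beyond the scatter)). The recovery is partial, as the ring carrying an amine still falls short of both chains bearing a hydroxyl, with the 3-amino-2-hydroxypropyl chain (a 2.2-fold higher number from compound 2 to compound 4 (0.34 log units; beyond the scatter)) closer than the 2,3-dihydroxypropyl chain (a 6.6-fold higher number from compound 1 to compound 4 (0.82 log units; beyond the scatter)), so the order of the series now runs from the dihydroxy chain through the amino alcohol and the aminocyclohexyl group to the diamine. Nothing available here accounts for these steps, and the change from compound 3 to compound 4 alters the ring and the amine count together, so their shares stay unseparated.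

Open, on these data alone, is what an unsubstituted cyclohexyl group or a 2-hydroxycyclohexyl group would give on the same sulfur, and either would separate the ring from its amine. Also open, as far as these compounds go, is whether a cyclopentyl ring bearing an amine, or a 2,3-dihydroxycyclohexyl group that pairs the ring with the hydroxyls of compound 1, would follow the same order.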